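The source may report more compounds than this note shows. Statements on the series, on what has been measured and on what is new or still open speak of the compounds shown alone.

Measured so far:
compound 1 `CC1CCC(=NNc2ccc(Cl)cc2Cl)c2ncc(C(=O)O)c(=O)n21`: > 100 umol/kg
compound 2 `CC1CCC(C)(N=Nc2ccccc2)c2ncc(C(=O)O)c(=O)n21`: > 100 umol/kg

In a functional assay on the whole organism with Rattus norvegicus as the target (on this read-out higher numbers stand for an effect only at larger amounts of compound and lower numbers for an effect already at smaller amounts), compound 1 gives > 100 umol/kg, a limit of the assay and not a number. Compound 2 also gives only a limit, > 100 umol/kg. Among the measured compounds shown here, both sit at the limit of > 100 umol/kg in this assay, at which 2 of the 2 values shown sit, so compound 2 stands at the limit, with no measured step to any other compound. Compound 3 `CC1CCC(C)(N=Nc2ccccc2C(=O)O)c2ncc(C(=O)O)c(=O)n21` differs from compound 2 by carboxy in place of hydrogen on an aromatic carbon. For the measured compounds named here, with no step measured, no change beyond the scatter is expected in either direction. Compound 3 is expected to give 150 umol/kg, between 40 umol/kg and 500 umol/kg, most likely again as a limit. The expected step that the limit leaves unreadable from compound 2 to compound 3 is accordingly small.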

Compound 3, dose for 50% inhibition: > 100 umol/kg
Compound 3 ended at the assay's limit; the forecaster's own chance of this, stated with the estimate: 75%; the middle value is on the limit's open side.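

In this assay, among the compounds shown here, compound 2 and compound 3 both end at a limit of the assay, so no step between them can be read: the limit of > 100 umol/kg in this assay, at which 3 of the 3 values shown sit.
The compounds shown leave open whether carboxy in place of hydrogen on an aromatic carbon changes the read-out at all.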